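Cytotoxicity on Vero cells across a common core

The compounds below may be only part of what the source reports. "The series", "measured", "known", "first", "only" and "open" are said of these compounds alone.

Measured compounds:
- compound 1, `CN1Cc2ccc(OCCC3CCCCC3)cc2[C@@H](O)C1`: > 50000 nM
- compound 2, `COCCOCOc1ccc2c(c1)[C@@H](O)CN(C)C2`: > 50000 nM
- compound 3, `CN1Cc2ccc(OCc3cccc(Br)c3)cc2[C@@H](O)C1`: 60300 nM

In an ADME assay on Vero cells (Chlorocebus sabaeus) for cytotoxicity, read by sulforhodamine B assay, with a stated time of 72 h (on this read-out higher numbers stand for weaker inhibition and lower numbers for stronger inhibition), compound 1 returns only a limit, > 50000 nM. Compound 2 likewise returns only a limit in this assay, > 50000 nM. Going by the values given here, compound 3 is the single compound of the three with a read number in this assay, 60300 nM. The steps a step that the two limits leave unreadable from compound 1 to compound 2, a step that the limit leaves unreadable from compound 1 to compound 3 and a step that the limit leaves unreadable from compound 2 to compound 3 cannot be sized, because of the limit of > 50000 nM in this assay, at which 2 of the 3 values shown sit.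

The next compound, compound 4, `CN1Cc2ccc(OCc3cccc(-c4ccc(Cl)cc4)c3)cc2[C@@H](O)C1`, differs from compound 3 by 4-chlorophenyl in place of bromo on an aromatic carbon. Among the compounds with values here, no measured step bears on this change: every step that is known is unreadable, so no direction or size can be carried over, and the number of compound 3 is the only anchor. The working expectation is that compound 4 stays near compound 3 in this assay, with the step of a 1.3-fold lower number from compound 3 to compound 4 (0.13 log units; within the scatter) not expected to exceed the scatter. The estimate for compound 4 in this assay is 45000 nM, with a range from 15000 nM to 100000 nM.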

Compound 4, half-maximal inhibitory concentration: 27300 nM
Compound 4: middle estimate off by 1.6-fold (0.22 log units), on the high side, and the stated range covers the measured number.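

Going by these compounds alone, on this aromatic carbon, meta to a large group, 4-chlorophenyl in place of bromo gives the first step that can be read in this assay: a 2.2-fold lower number from compound 3 to compound 4 (0.34 log units; beyond the scatter). The position is therefore not silent on this read-out: a change that brings in one six-membered aromatic ring of carbon only, with no hydrogen-bond donor or acceptor, moves the number beyond the scatter, though modestly. The earlier steps among compound 1, compound 2 and compound 3 cannot be read because of the assay limit: the limit of > 50000 nM in this assay, at which 2 of the 4 values shown sit.

A single change cannot separate the contribution of the new ring, its chlorine and the loss of bromine. From the compounds shown here alone, whether an amine, a carboxylic acid or a simple methyl on this carbon would shift the number in the same direction in this assay remains open.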